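This account rests on a few compounds, and the source may have more. Where it says the series, first, only, none or still open, it means among the compounds named here.

Measured compounds:
compound 1, `Nc1cc(Cc2ccn(Cc3ccc4ccccc4c3)n2)c2nn[nH]c2n1`, in an assay on cells for inhibition of thyroid peroxidase (Homo sapiens), with stated times of 10 min and 15 min (a lower number here means a stronger inhibitor, a higher number a weaker inhibitor), compound 1 gives 1100 nM
compound 2, `Nc1cc(Cc2ccn(-c3cccc(-c4ccccc4)c3)n2)c2nn[nH]c2n1`, in this assay compound 2 gives 710 nM

Compound 2 has the lower of the two numbers, but compound 1 stands within the usual scatter of it, so the two cannot be placed in any order. Compound 3, `Nc1cc(Cc2ccn(-c3ccccc3)n2)c2nn[nH]c2n1`, has not yet been measured. It differs from compound 2 in one place: hydrogen in place of phenyl on an aromatic carbon, the change sitting on the ring that is attached directly to the nitrogen of the shared core. Going by the values given here, no measured pair shows what such a removal does here, so the expectation rests on the fact that both measured compounds carry a large aromatic piece at that end of the molecule. Taking the phenyl away is expected to give a moderately higher number in this assay, a step of about a 2.8-fold higher number from compound 2 to compound 3 (0.45 log units; beyond the scatter), though a result within the scatter cannot be ruled out. Compound 3 is therefore estimated at 2000 nM, with a plausible range from 700 nM to 6000 nM.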

Compound 3, half-maximal inhibitory concentration: 640 nM
Estimate against measurement, compound 3: 3.1-fold (0.49 log units) above; measured number below the stated range.
By their numbers in this assay, from the lowest: compounds 3, 2 and 1 (each within the scatter of the next).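

In this assay, taking the phenyl off the ring attached directly to the nitrogen of the shared core gives a 1.1-fold lower number from compound 2 to compound 3 (0.05 log units; within the scatter), so removing this group makes no difference that can be told apart from the scatter. Going by these compounds alone, this is the first direct reading at this position: the second aromatic ring of compound 2 is not needed to keep a number of this size, and the single ring on the nitrogen in compound 3 is enough. No supporting measurement bears on this result.

From the compounds shown here alone, only hydrogen and phenyl are compared at this place, so it remains open whether an amine, a carboxylic acid or a methoxy group there would shift the number. Also open, going by these compounds, is what replacing the ring on the nitrogen with a short alkyl chain would do.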